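The source may report more compounds than this note shows. Statements on the series, on what has been measured and on what is new or still open speak of the compounds shown alone.

Measured in a functional assay on MCF7 cells (Homo sapiens) for antiproliferative activity, read by MTT assay, with a stated time of 48 h (a higher number here means a weaker inhibitor, a lower number a stronger inhibitor), so far:
Compound 1 `COc1ccc(C(=O)c2ccc(OC)c3c2C=CC(C)(C)O3)c(NC(=O)CO)c1` gives 940 nM
Compound 2 `COc1ccc(C(=O)c2cc(OC)c(OC)c(OC)c2)c(NC(=O)CO)c1` gives 230 nM

Compound 2 holds the lower of the two numbers, and compound 1 lies above it by a gap beyond the scatter. Compound 3 `COc1ccc(C(=O)c2cc(OC)c(OC)c(OC)c2)c(NC(=O)CN)c1` differs from compound 2 by amino in place of hydroxy on a saturated chain carbon bound to a carbonyl carbon with amino in place of hydroxy on a saturated chain carbon bound to a carbonyl carbon. Among the compounds with values here, no measured pair shows this exchange. The expected step of a 1.2-fold lower number from compound 2 to compound 3 (0.06 log units; within the scatter) is small and is not expected to go beyond the scatter. In this assay compound 3 is estimated at 200 nM with an expected range of 50 nM to 800 nM as a working figure.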

Compound 3, half-maximal inhibitory concentration: 270 nM
Compound 3: the middle estimate sits 1.4-fold (0.13 log units) below what was measured, and the stated range covers the measured number.
By their numbers in this assay, from the lowest: compounds 2 and 3 (each within the scatter of the next); then compound 1.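

In this assay amino in place of hydroxy on a saturated chain carbon bound to a carbonyl carbon gives a 1.2-fold higher number from compound 2 to compound 3 (0.07 log units; within the scatter) and so leaves the number within the scatter. Within the data shown here, this is the first step at this position, and it shows that either group serves equally well here on the core of compound 2. No evidence accounts for this result.

Still open, as far as these compounds go, is whether a carboxylic acid, a dimethylamino group or a longer chain at this place would hold up as well. From the compounds shown here alone, whether the same exchange behaves alike on the core of compound 1 also remains open.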